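The source may report more compounds than this note shows. Statements on the series, on what has been measured and on what is new or still open speak of the compounds shown alone.

Measured so far:
compound 1 `CCCCCCCCCCCCCCNC(=O)[C@@H](NC(=O)/C=C/c1ccccc1)[C@@H](C)O` — in a functional assay on MCF7 cells (Homo sapiens) for cytotoxicity, read by MTT assay, with a stated time of 48 h (on this read-out higher numbers stand for weaker inhibition and lower numbers for stronger inhibition), compound 1 gives 64600 nM
compound 2 `CCCCCCCCCCCCCCNC(=O)[C@@H](NS(=O)(=O)c1ccc(C)cc1)[C@@H](C)O` — in this assay compound 2 gives 12900 nM

Going by the values given here, compound 1 stands at the higher of the two numbers, and its only measured neighbour is compound 2, reached by a 5.0-fold lower number from compound 1 to compound 2 (0.70 log units; beyond the scatter) through (4-methylphenyl)sulfonyl in place of (2-phenylethenyl)carbonyl on an amine nitrogen. Compound 3 `CCCCCCCCCCCCCCCCCCNC(=O)[C@@H](NC(=O)/C=C/c1ccccc1)[C@@H](C)O` is not yet measured. It differs from compound 1 by butyl in place of hydrogen on a saturated chain carbon, ten or more bonds along the chain from an amide-type nitrogen; the same difference, cut one bond further out, reads methyl to pentyl. Among the compounds with values here, no measured step touches the saturated chain at all; the single step known, from compound 1 to compound 2, alters the amide cap and therefore gives no guide here. With nothing to draw on, the expected step in this assay is none beyond the scatter, in either direction, which is what a 1.1-fold lower number from compound 1 to compound 3 (0.03 log units; within the scatter) expresses. Compound 3 is accordingly estimated at 60000 nM, with a range from 20000 nM to 180000 nM.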

Compound 3, half-maximal inhibitory concentration: 39200 nM
The estimate for compound 3 lay 1.5-fold (0.18 log units) above the measured number, and the stated range covers the measured number.
By their numbers in this assay, from the lowest: compound 2; then compounds 3 and 1 (each within the scatter of the next).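

In this assay, going by these compounds alone, this is the first measured change to the saturated chain, and it gives a 1.6-fold lower number from compound 1 to compound 3 (0.22 log units; within the scatter). Butyl in place of hydrogen at this place on the chain therefore leaves the read-out within the scatter, whereas the only step beyond the scatter among the compounds shown remains the change on the amine nitrogen. Nothing available explains this result.

The compounds shown leave open whether the chain would matter more if shortened to octyl, or if it ended in an amine or a carboxylic acid instead of a plain methyl. They also leave open whether the same butyl change would behave alike with the (4-methylphenyl)sulfonyl group of compound 2 on the amine nitrogen.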